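This account rests on a few compounds, and the source may have more. Where it says the series, first, only, none or still open, it means among the compounds named here.

In a functional assay on PC-3 cells (Homo sapiens) for cytotoxicity, read by MTT assay, with a stated time of 72 h (a lower number here means a stronger inhibitor, a higher number a weaker inhibitor), compound 1 `COc1ccc(OC)c(C(=O)/C=C/c2ccc(C(=O)O)cc2)c1` gives 7240 nM, the highest number of the three, though its steps to the others stay within the scatter. In this assay compound 2 `CCOC(=O)c1ccc(/C=C/C(=O)c2cc(OC)ccc2OC)cc1` gives 5700 nM, and compound 3 `CCN(CC)C(=O)c1ccc(/C=C/C(=O)c2cc(OC)ccc2OC)cc1` gives 3790 nM. The steps of a 1.3-fold lower number from compound 1 to compound 2 (0.10 log units; within the scatter), a 1.9-fold lower number from compound 1 to compound 3 (0.28 log units; within the scatter) and a 1.5-fold lower number from compound 2 to compound 3 (0.18 log units; within the scatter) are all within the scatter. Compound 4 `COc1ccc(OC)c(C(=O)/C=C/c2ccc(C(=O)N3CCCC3)cc2)c1` differs from compound 1 by pyrrolidin-1-yl in place of hydroxy on a carbonyl carbon. Going by the values given here, the closest precedent is a 1.9-fold lower number from compound 1 to compound 3 (0.28 log units; within the scatter), where diethylamino replaced hydroxy on a carbonyl carbon; a 1.5-fold lower number from compound 2 to compound 3 (0.18 log units; within the scatter) points the same way. Compound 4 is therefore expected to show only a small lowering, a 1.9-fold lower number from compound 1 to compound 4 (0.28 log units; within the scatter), which stays within the scatter. Compound 4 is estimated at 3800 nM, with a range of 1600 nM to 9000 nM.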

Compound 4, half-maximal inhibitory concentration: 530 nM
Compound 4: middle estimate off by 7.2-fold (0.86 log units), on the high side, and the stated range ends above it.
By their numbers in this assay, from the lowest: compound 4; then compounds 3, 2 and 1 (each within the scatter of the next).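

In this assay, going by these compounds alone, the group on the carbonyl carbon proves to matter beyond simply replacing hydroxy, as the earlier steps, all within the scatter, did not show: a 14-fold lower number from compound 1 to compound 4 (1.14 log units; beyond the scatter) and an 11-fold lower number from compound 2 to compound 4 (1.03 log units; beyond the scatter) are both beyond it. Amide formation alone does not account for this, since diethylamino is also an amide-forming group and a 7.2-fold lower number from compound 3 to compound 4 (0.85 log units; beyond the scatter) still separates it from pyrrolidin-1-yl. Nothing available explains the difference.

On these data alone, whether it extends to other cyclic amines, such as piperidine or morpholine, remains open. So does how a smaller open-chain group such as dimethylamino would compare.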